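Pyrrolidinyl for dimethylamino on the bridged core: cytotoxicity notes

The source may report more compounds than this note shows. Statements on the series, on what has been measured and on what is new or still open speak of the compounds shown alone.

Measured in an ADME assay on L6 cells (Rattus norvegicus) for cytotoxicity; a higher number here means a weaker inhibitor, a lower number a stronger inhibitor:
compound 1 `CN(C)C12CC(OC(=O)CN3CCCC3)C(C(c3ccccc3)C1)C(c1ccccc1)C2` gives 32700 nM
compound 2 `O=C(CN1CCCC1)OC1CC2(N3CCCC3)CC(c3ccccc3)C1C(c1ccccc1)C2` gives 42900 nM
compound 3 `CN(C)C12CC(OC(=O)CCN3CCCC3)C(C(c3ccccc3)C1)C(c1ccccc1)C2` gives 26000 nM

The change pyrrolidin-1-yl in place of dimethylamino on a saturated ring carbon gave a 1.3-fold higher number from compound 1 to compound 2 (0.12 log units; within the scatter). Compound 3 differs from compound 1 by (pyrrolidin-1-yl)methyl in place of pyrrolidin-1-yl on a saturated chain carbon bound to a carbonyl carbon, and this gave a 1.3-fold lower number from compound 1 to compound 3 (0.10 log units; within the scatter). All three values sit within the scatter of one another, so no ordering among them is claimed.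

Compound 4 `O=C(CCN1CCCC1)OC1CC2(N3CCCC3)CC(c3ccccc3)C1C(c1ccccc1)C2` is not yet measured. It differs from compound 3 by pyrrolidin-1-yl in place of dimethylamino on a saturated ring carbon. This is the same kind of change as from compound 1 to compound 2, but around the place the ring atom bears a ((2-(pyrrolidin-1-yl)ethyl)carbonyl)oxy group rather than a (((pyrrolidin-1-yl)methyl)carbonyl)oxy group.

Compound 4 is expected to give 34000 nM in this assay. For compound 4 the estimated range runs from 17000 nM to 68000 nM. The expected step is a 1.3-fold higher number from compound 3 to compound 4 (0.12 log units; within the scatter), a step of about the size seen beside it as a 1.3-fold higher number from compound 1 to compound 2 (0.12 log units; within the scatter), on which, together with compound 3 giving 26000 nM, the estimate rests.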

Compound 4, half-maximal inhibitory concentration: 21900 nM
For compound 4 the middle estimate is 1.6-fold (0.19 log units) above the measured one, and the stated range covers the measured number.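

In this assay, pyrrolidin-1-yl in place of dimethylamino on the saturated ring carbon gives a 1.2-fold lower number from compound 3 to compound 4 (0.07 log units; within the scatter), and this agrees with the earlier step on the other core: the same change on two cores in this assay, a 1.3-fold higher number (0.12 log units; within the scatter) from compound 1 to compound 2 and a 1.2-fold lower number (0.07 log units; within the scatter) from compound 3 to compound 4, 1.6-fold (0.19 log units) apart, within the scatter of two such steps. The chain change, (pyrrolidin-1-yl)methyl in place of pyrrolidin-1-yl, gives a 2.0-fold lower number from compound 2 to compound 4 (0.29 log units; within the scatter), and this also agrees with its earlier step: the same change on two cores in this assay, a 1.3-fold lower number (0.10 log units; within the scatter) from compound 1 to compound 3 and a 2.0-fold lower number (0.29 log units; within the scatter) from compound 2 to compound 4, 1.6-fold (0.19 log units) apart, within the scatter of two such steps. For the compounds shown here, neither change moves the number beyond the scatter on either core, so the agreement shows only that both steps stay small, and it gives neither change a direction.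

Open, as far as these compounds go, is whether a piperidin-1-yl or morpholin-4-yl group in place of either pyrrolidin-1-yl would give a step beyond the scatter. The same question stands for a primary amine on the ring carbon or a longer chain before the terminal amine.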